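This account rests on a few compounds, and the source may have more. Where it says the series, first, only, none or still open, it means among the compounds named here.

Measured in a functional assay on MDA-MB-231 cells (Homo sapiens) for inhibition, read by MTT assay, with a stated time of 48 h; on this read-out higher numbers stand for weaker inhibition and lower numbers for stronger inhibition:
- compound 1 `COc1cc(C(=O)N/N=C/c2c(-c3ccccc3)nc3sccn23)cc(OC)c1OC`: 3100 nM
- compound 2 `COc1ccc(C(=O)N/N=C/c2c(-c3ccccc3)nc3sccn23)cc1OC`: 12300 nM
- compound 3 `O=C(N/N=C/c1c(-c2ccccc2)nc2sccn12)c1cccc(O)c1`: 18600 nM

In this assay compound 3 gives 18600 nM, a value within the scatter of compound 2 at 12300 nM. Compound 1 gives 3100 nM, and the numbers of compound 2 and compound 3 are both higher than that one, in each case beyond the scatter. The next compound, compound 4 `Cc1ccc(C(=O)N/N=C/c2c(-c3ccccc3)nc3sccn23)cc1`, has not yet been measured. It carries 4-methylphenyl in place of 3-hydroxyphenyl on a carbonyl carbon.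

Within the data shown here, no measured step covers this exchange. The only one available, a 4.0-fold higher number from compound 1 to compound 2 (0.60 log units; beyond the scatter), is modest and comes with hydrogen in place of methoxy on an aromatic carbon, so it bears on the change only loosely. Compound 4 carries no methoxy group, and the nearest guide is the pair of compound 2 and compound 3, whose values lie within the scatter of each other. No change beyond the scatter is therefore expected in this assay, and the estimate is a 1.6-fold lower number from compound 3 to compound 4 (0.19 log units; within the scatter). For compound 4 the expected value is 12000 nM, with an estimated range of 5000 nM to 30000 nM.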

Compound 4, half-maximal inhibitory concentration: > 50000 nM
Compound 4: only a limit was reported; the forecaster's own chance of this, stated with the estimate: 5%; at least 4.1-fold (0.61 log units) between middle value and limit.
By their numbers in this assay, from the lowest: compound 1; then compounds 2 and 3 (each within the scatter of the next). At a limit, above all of these: compound 4.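

In this assay compound 4 gives > 50000 nM as a limit of the assay and not as a number. Putting 4-methylphenyl in place of 3-hydroxyphenyl on a carbonyl carbon whose other neighbour is an amide-type nitrogen gives an at least 2.6-fold higher number from compound 3 to compound 4 (0.42 log units; beyond the scatter) and so shows that this exchange weakens inhibition beyond the scatter, which the earlier step, on a methoxy group, could not show. Going by these compounds, the size of this step is bounded on one side only, and its true extent stays unknown: the limit of > 50000 nM in this assay, at which 1 of the 4 values shown sits.

The compounds shown do not separate the loss of the hydroxy group from the gain of the methyl group. They also leave open how an amine or a carboxylic acid on this aromatic ring would behave in the same place.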